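The source may report more compounds than this note shows. Statements on the series, on what has been measured and on what is new or still open speak of the compounds shown alone.

Compound 3 `CC(C)(C)OC(=O)CC[C@H]1N=C2C[C@H]3C[C@H](C3(C)C)[C@@]2(C)OC1=O` is the reference point of this step. In an ADME assay on MCF-10A cells (Homo sapiens) for antiproliferative activity, read by sulforhodamine B assay, with a stated time of 48 h (a lower number here means a stronger inhibitor, a higher number a weaker inhibitor), compound 3 gives only a limit, > 1200000 nM. Compound 2 `CC1(C)[C@H]2CC3=N[C@H](CCC(=O)O)C(=O)O[C@]3(C)[C@@H]1C2` likewise reaches only a limit in this assay, > 1200000 nM. Compound 1 `CC(C)(C)OC(=O)NCCC[C@@H]1N=C2C[C@@H]3C[C@@H](C3(C)C)[C@]2(C)OC1=O` in this assay also stops at a limit, > 1200000 nM. Going by the values given here, the single measured step, from compound 2 to compound 3, is a step that the two limits leave unreadable from compound 2 to compound 3, its size hidden because both ends sit at the limit of > 1200000 nM in this assay, at which 3 of the 3 values shown sit.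

Compound 4 `CC(C)(C)OC(=O)CC[C@@H]1N=C2C[C@@H]3C[C@@H](C3(C)C)[C@]2(C)OC1=O` differs from compound 3 in that (the two compounds have the same atoms and bonds and differ only in configuration as drawn: 4 of 4 stereo elements differ (all stereocentres are inverted: mirror images); a stereocentre at a saturated ring carbon is drawn R in compound 3 and S in compound 4; a stereocentre at a saturated ring carbon is drawn R in compound 3 and S in compound 4; a stereocentre at a saturated ring carbon is drawn R in compound 3 and S in compound 4; a stereocentre at a saturated ring carbon is drawn R in compound 3 and S in compound 4). Among the compounds with values here, no measured step concerns an inversion of all stereocentres, so nothing read so far gives a size or direction for this change. With every value to date resting at the limit of > 1200000 nM in this assay, at which 3 of the 3 values shown sit, compound 4 is expected to remain at that limit as well. The step from compound 3 to compound 4 is estimated as a number no higher from compound 3 to compound 4 (the limit leaves the size open). For compound 4 the estimate in this assay is 1200000 nM, between 600000 nM and 2400000 nM.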

Compound 4, half-maximal inhibitory concentration: > 1000000 nM
Compound 4 ended at the assay's limit; the forecaster's own chance of this, stated with the estimate: 90%; the middle value lies beyond the limit too.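

Going by these compounds alone, compound 3 and compound 4 both stop at a limit, and no step between them can be read. The compounds shown leave open whether inverting all stereocentres changes activity at all, and which structure would give a value short of a limit.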